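From Fluoro to 1-Methylethenyl on the Shared Core

The source may report more compounds than this note shows. Statements on the series, on what has been measured and on what is new or still open speak of the compounds shown alone.

Measured compounds:
compound 1, `CN1CCCN(CCn2ccc3ccc(F)cc32)CC1`: 288 nM
compound 2, `CN1CCCN(CCn2ccc3ccc(OCc4ccccc4)cc32)CC1`: 182 nM
compound 3, `CCc1ccc2ccn(CCN3CCCN(C)CC3)c2c1`: 166 nM

Three compounds share one core and differ only in the group on an aromatic carbon. In an assay on HEK293 cells for binding affinity to 5-hydroxytryptamine receptor 7 (Homo sapiens), read by radioligand binding (on this read-out lower numbers stand for stronger inhibition and higher numbers for weaker inhibition), compound 1 gives the highest of the three numbers; the two others sit close to it, with a 1.6-fold lower number from compound 1 to compound 2 (0.20 log units; within the scatter) and a 1.7-fold lower number from compound 1 to compound 3 (0.24 log units; within the scatter), and a 1.1-fold lower number from compound 2 to compound 3 (0.04 log units; within the scatter) between those two. None of these steps leaves the scatter, so the three values show no order among them.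

Compound 4, `C=C(C)c1ccc2ccn(CCN3CCCN(C)CC3)c2c1`, is not yet measured. It differs from compound 1 as follows: 1-methylethenyl in place of fluoro on an aromatic carbon.

For the measured compounds named here, the steps that bear on this change are the two replacements of the fluoro on compound 1 by a larger carbon group, a 1.6-fold lower number from compound 1 to compound 2 (0.20 log units; within the scatter) and a 1.7-fold lower number from compound 1 to compound 3 (0.24 log units; within the scatter). Both are small and both run toward a lower number, but neither is beyond the scatter. The 1-methylethenyl group in compound 4 resembles the ethyl of compound 3 most closely in size. A step of the same kind is therefore expected, a 1.6-fold lower number from compound 1 to compound 4 (0.20 log units; within the scatter), and no larger.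

Compound 4 is thus estimated at 180 nM in this assay, with a range from 80 nM to 400 nM.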

Compound 4, inhibition constant: 70 nM
The estimate for compound 4 lay 2.6-fold (0.41 log units) above the measured number; measured number below the stated range.
By their numbers in this assay, from the lowest: compound 4; then compounds 3, 2 and 1 (each within the scatter of the next).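

In this assay, for the compounds shown here, 1-methylethenyl is the only group among the four on this aromatic carbon whose steps leave the scatter, with a 4.1-fold lower number from compound 1 to compound 4 (0.61 log units; beyond the scatter) in the replacement of fluoro, while fluoro, benzyloxy and ethyl could not be told apart. The change from ethyl, the closest comparison, still gives a 2.4-fold lower number from compound 3 to compound 4 (0.38 log units; beyond the scatter) on the same core, and the change from benzyloxy gives a 2.6-fold lower number from compound 2 to compound 4 (0.41 log units; beyond the scatter) of much the same size, so this position does respond to the choice of group. The data offer no measurement that would explain why this group stands apart.

The saturated 1-methylethyl group does not appear among these compounds, so it stays open whether the double bond or the branching goes with the lower number. On these data alone, how an amine or a carboxylic acid would read on this carbon also remains open.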